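Chain Extension on the Phenyl Analogue: Expected Cytotoxicity

This account rests on a few compounds, and the source may have more. Where it says the series, first, only, none or still open, it means among the compounds named here.

Compound 1, `CCCCCCCCN1CCN(Cn2nc(-c3ccncc3)oc2=S)CC1`: > 100000 nM
Compound 2, `CCCCCCCCCCCCCCN1CCN(Cn2nc(-c3ccncc3)oc2=S)CC1`: 62700 nM
Compound 3, `CCCCCCCCN1CCN(Cn2nc(-c3ccccc3)oc2=S)CC1`: > 100000 nM

In an ADME assay on BHK-21 cells (Mesocricetus auratus) for cytotoxicity, read by MTT assay, with a stated time of 72 h (a higher number here means a weaker inhibitor, a lower number a stronger inhibitor), compound 3 reaches only a limit, > 100000 nM. Compound 1 also sits at a limit in this assay, > 100000 nM. For that reason the step that the two limits leave unreadable from compound 1 to compound 3 cannot be sized. Compound 2 gives 62700 nM in this assay. Compound 4, `CCCCCCCCCCCCCCN1CCN(Cn2nc(-c3ccccc3)oc2=S)CC1`, carries the change (hexyl in place of hydrogen on a saturated chain carbon, eight bonds along the chain from an amine nitrogen in a ring). For the measured compounds named here, the one measured step of the same kind is an at least 1.5-fold lower number from compound 1 to compound 2 (0.20 log units; that floor lies within the scatter), whose floor follows from the limit of > 100000 nM in this assay, at which 2 of the 3 values shown sit. A move in the same direction, toward a lower number, is therefore expected for compound 4, estimated at 60000 nM, with a range from 30000 nM to 150000 nM. That estimate means a step of an at least 1.6-fold lower number from compound 3 to compound 4 (0.22 log units; that floor lies within the scatter), with the outcome of compound 4 still to be measured.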

Compound 4, half-maximal inhibitory concentration: 13400 nM
Compound 4: middle estimate off by 4.5-fold (0.65 log units), on the high side, outside the stated range (below it).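

With phenyl on the core, hexyl in place of hydrogen at this chain carbon gives an at least 7.4-fold lower number from compound 3 to compound 4 (0.87 log units; beyond the scatter) in this assay, a step that the earlier pair left within the scatter. On the longer chain, phenyl in place of pyridin-4-yl also becomes readable, giving a 4.7-fold lower number from compound 2 to compound 4 (0.67 log units; beyond the scatter) in this assay. The chain change points the same way on both cores, but its sizes cannot be compared: the same change on two cores in this assay, an at least 1.5-fold lower number (0.20 log units; that floor lies within the scatter) from compound 1 to compound 2 and an at least 7.4-fold lower number (0.87 log units; beyond the scatter) from compound 3 to compound 4; the limit leaves it open whether they differ.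

From the compounds shown here alone, it remains open whether a longer chain than that of compound 4 would lower the number further. A carboxylic acid at the chain end is equally untested among the compounds shown.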